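From Methylpiperazine to Trifluoromethoxyphenylamino on a Shared Core

The source may report more compounds than this note shows. Statements on the series, on what has been measured and on what is new or still open speak of the compounds shown alone.

Of the compounds shown here, three have been measured in a functional assay on HCT-116 cells (Homo sapiens) for antiproliferative activity, read by CCK-8 assay, with a stated time of 72 h, tested at 2 uM; a higher number here means a stronger effect of the compound at the concentration tested, a lower number a weaker effect. Compound 1 `CN1CCN(c2nc(Cl)nc3c2ncn3Cc2ccc(C(=O)Nc3ccccc3N)cc2)CC1` gives 71.6% in this assay, the highest of the three numbers. Compound 2 `CC(C)n1cnc2c(Nc3cccc(Cl)c3)nc(NCOCc3ccc(C(=O)Nc4ccccc4N)cc3)nc21` gives 7.12%, and compound 3 `CCCCn1cnc2c(Nc3ccccc3)nc(NCOCc3ccc(/C=C/C(=O)Nc4ccccc4N)cc3)nc21` gives 6.58%; both lie far beneath compound 1, by margins well beyond the usual scatter, while the two weaker compounds sit within the scatter of each other. Going by the values given here, compounds 2 and 3 differ from compound 1 in more than one place, so no single step between measured compounds can be drawn.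

The compound now in question is compound 4 `Nc1ccccc1NC(=O)c1ccc(Cn2cnc3c(Nc4cccc(OC(F)(F)F)c4)nc(Cl)nc32)cc1`, which differs from compound 1 by one change: (3-(trifluoromethoxy)phenyl)amino in place of 4-methylpiperazin-1-yl on an aromatic carbon. Compound 4 keeps the rest of compound 1 intact, including the chloro group and the benzamide portion.

Among the compounds with values here, no measured pair shows what this exchange alone does. The two measured compounds that carry an arylamino group on the core, compounds 2 and 3, are weak, yet they also differ elsewhere, so their numbers cannot be read as the effect of this change. A downward step from compound 1 to compound 4 is nonetheless expected, estimated at a number 26.6 percentage points lower from compound 1 to compound 4 (beyond the scatter), with wide uncertainty. Compound 4 is therefore expected to give about 45% in this assay, within a range of 15% to 75%.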

Compound 4, a percentage reported as inhibition, at one concentration (the size of the read-out at that concentration, not a potency): 1.6%
Estimate against measurement, compound 4: 43.4 percentage points above; measured number outside the range, below it.
By their numbers in this assay, from the lowest: compounds 4, 3 and 2 (each within the scatter of the next); then compound 1.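

In this assay, putting (3-(trifluoromethoxy)phenyl)amino in place of 4-methylpiperazin-1-yl on the aromatic carbon, with the chloro group and the benzamide portion unchanged, gives a number 70 percentage points lower from compound 1 to compound 4 (beyond the scatter). Going by these compounds alone, compounds 2 and 3 also carry an arylamino group on the core, but they differ from compound 1 in more than one place, so only this pair ties a large loss of effect at the tested concentration to this one exchange and shows that the high number of compound 1 does not survive it. The data shown give the size of this step but offer no measurement that would explain it.

As far as these compounds go, it remains open whether the number of compound 1 depends on the 4-methylpiperazin-1-yl group itself or would persist with another saturated amine on the same carbon, such as morpholin-4-yl, piperazin-1-yl or dimethylamino. From the compounds shown here alone, it is equally open how much of the step belongs to the phenylamino part and how much to the trifluoromethoxy group, which a plain phenylamino or a 3-chlorophenylamino group on the core of compound 1 could separate.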